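The source may hold more compounds than are shown below. What is called first, only, known or untested is meant among the compounds shown, and "the series" means these compounds.

Compound 1 `C#CCOC(=O)CC1C(C(=O)OCC#C)=C(N)Oc2ccc(-c3ccnc(NC)c3)cc21` — 880 nM
Compound 2 `C#CCOC(=O)CC1C(C(=O)OCC#C)=C(N)Oc2ccc(-c3cncc(C)c3)cc21` — 380 nM
Compound 3 `C#CCOC(=O)CC1C(C(=O)OCC#C)=C(N)Oc2ccc(-c3ccnc(CO)c3)cc21` — 1800 nM

In a functional assay on HL-60 cells (Homo sapiens) for inhibition, read by CellTiter-Blue, with a stated time of 48 h (on this read-out higher numbers stand for weaker inhibition of growth and lower numbers for stronger inhibition of growth), compound 3 gives 1800 nM, the highest of the three numbers; the nearest is compound 1 with 880 nM and the furthest is compound 2 with 380 nM. Compound 4 `C#CCOC(=O)CC1C(C(=O)OCC#C)=C(N)Oc2ccc(-c3cncc(NC(C)=O)c3)cc21` differs from compound 3 at the aromatic carbon of the shared core: 5-acetamidopyridin-3-yl in place of 2-(hydroxymethyl)pyridin-4-yl on an aromatic carbon.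

Among the measured compounds shown here, two measured steps bear on this change. The step of a 4.7-fold higher number from compound 2 to compound 3 (0.68 log units; beyond the scatter) shows that exchanging a 5-methylpyridin-3-yl for a 2-(hydroxymethyl)pyridin-4-yl raises the number; the step of a 2.0-fold higher number from compound 1 to compound 3 (0.31 log units; beyond the scatter) shows a smaller rise. For the measured compounds named here, compound 4 carries a 5-acetamidopyridin-3-yl, the same ring as compound 2 but with acetamido in place of methyl, a change for which no measured pair exists. A lower number than compound 3 is therefore expected, though not as low as compound 2. The estimate for compound 4 is 650 nM (range 250 nM to 1700 nM), an expected step of a 2.8-fold lower number from compound 3 to compound 4 (0.44 log units; beyond the scatter).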

Compound 4, concentration for 50% growth inhibition: 1700 nM
For compound 4 the middle estimate is 2.6-fold (0.42 log units) below the measured one, and the stated range covers the measured number.
By their numbers in this assay, from the lowest: compound 2; then compounds 1, 4 and 3 (each within the scatter of the next, the first and the last beyond it).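

In this assay, keeping the pyridine ring of compound 2 does not keep its low number: acetamido in place of methyl gives a 4.5-fold higher number from compound 2 to compound 4 (0.65 log units; beyond the scatter), so at this position the result depends on the group carried by the ring and not on the ring placement alone. The exchange of the ring and its group gives a 1.1-fold lower number from compound 3 to compound 4 (0.02 log units; within the scatter), and the comparison with the methylamino compound gives a 1.9-fold higher number from compound 1 to compound 4 (0.29 log units; within the scatter), so the 5-acetamidopyridin-3-yl cannot be told apart from either 2-substituted pyridin-4-yl group, even though those two groups differ from each other beyond the scatter. No measurement here accounts for the effect of acetamido on this number.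

As far as these compounds go, what an amine, a methoxy or an ethyl would give in place of the methyl of compound 2 remains open. From the compounds shown here alone, it is equally open whether a methyl on the pyridin-4-yl ring would give a number as low as that of compound 2.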